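The source may report more compounds than this note shows. Statements on the series, on what has been measured and on what is new or still open speak of the compounds shown alone.

Measured compounds:
- compound 1 `CC(=O)c1c(C)nn(CCCN2CCN(c3ccc(C)cc3)CC2)c(=O)c1N` — 19%
- compound 2 `CCCC(=O)c1c(C)nn(CCCN2CCN(c3ccc(C)cc3)CC2)c(=O)c1N` — 0%
- compound 3 `C/C=C/c1c(C)nn(CCCN2CCN(c3ccc(C)cc3)CC2)c(=O)c1N` — 0%

In a functional assay on the whole organism (Abdomen, strain Swiss) for inhibition, with Mus musculus as the target, with stated times of 30 min, 10 min and 5 min, at a dose of 10 mg/kg by the oral route (a higher number here means a stronger effect of the compound at the dose given, a lower number a weaker effect), compound 1 gives 19%. Compound 2 gives 0% and compound 3 gives 0% in this assay. Compound 3 therefore stands level with compound 2, the two together at the bottom of the three numbers, and it lies beyond the scatter only from compound 1, as the step of a number 19 percentage points lower from compound 1 to compound 3 (beyond the scatter) shows; the step of no change at the digits printed from compound 2 to compound 3 (within the scatter) is within the scatter.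

Compound 4 `CCC/C=C/c1c(C)nn(CCCN2CCN(c3ccc(C)cc3)CC2)c(=O)c1N` differs from compound 3 as follows: ethyl in place of hydrogen on a saturated chain carbon bound to a double-bonded chain carbon. Among the compounds with values here, the one measured step of the same kind, growing the chain by an ethyl on a saturated chain carbon, is a number 19 percentage points lower from compound 1 to compound 2 (beyond the scatter), a drop that took compound 2 to the floor of the read-out. Compound 3 already sits at that floor, so no further drop can be read, and a rise has no support in the numbers shown. The expected step is therefore a number 3 percentage points higher from compound 3 to compound 4 (within the scatter), nothing beyond the scatter. Compound 4 is estimated at 3%, within 0% to 15%.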

Compound 4, a percentage reported as inhibition, in the whole organism at one dose (the size of the read-out at that dose, not a potency): 0%
For compound 4 the middle estimate is 3 percentage points above the measured one; low and high end bracket the measured number.
By their numbers in this assay, from the lowest: compounds 2, 3 and 4 (each within the scatter of the next); then compound 1.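

In this assay, ethyl in place of hydrogen on a saturated chain carbon bound to a double-bonded chain carbon leaves the read-out unmoved, no change at the digits printed from compound 3 to compound 4 (within the scatter), so pent-1-en-1-yl reads the same as prop-1-en-1-yl. Within the data shown here, on the aromatic carbon the longer alkene also shows no change at the digits printed from compound 2 to compound 4 (within the scatter) and a number 19 percentage points lower from compound 1 to compound 4 (beyond the scatter), which leaves the acetyl of compound 1 as the only group of the four apart from the rest. The same ethyl change reads differently on the two cores, although compound 3 already sits at the floor of the read-out, where no further fall could appear: the same change on two cores in this assay, a number 19 percentage points lower (beyond the scatter) from compound 1 to compound 2 and no change at the digits printed (within the scatter) from compound 3 to compound 4, 19 percentage points apart, beyond the scatter of two such steps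

From the compounds shown here alone, whether a carboxylic acid, an amine or a plain propyl on this aromatic carbon would match or pass the acetyl stays open. The single dose also leaves open whether compounds reading at the floor differ at higher doses.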